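This account rests on a few compounds, and the source may have more. Where it says the series, first, only, none or still open, it means among the compounds named here.

For the measured compounds named here, in a physicochemical assay for solubility, in phosphate buffer, measured as thermodynamic solubility, at pH 7.4 (on this read-out lower numbers stand for lower solubility and higher numbers for higher solubility), only two compounds have numbers so far. Compound 1 (`CS(=O)(=O)NC(=O)CCc1cn(-c2ccc(F)cc2)nc1-c1ccc(Cl)cc1`) stands at 25000 nM and compound 2 (`CS(=O)(=O)NC(=O)CCc1cn(-c2ccc(Br)cc2)nc1-c1ccncc1`) at 185000 nM as the higher of the two, with a gap beyond the usual scatter. These two differ in more than one place, so the gap cannot be tied to any single group.

Compound 3 (`CS(=O)(=O)NC(=O)CCc1cn(-c2ccc(Br)cc2)nc1-c1ccc(N)cc1`) takes 4-aminophenyl in place of pyridin-4-yl on an aromatic carbon of compound 2 (4-aminophenyl in place of pyridin-4-yl on an aromatic carbon) and leaves the rest unchanged. Going by the values given here, no measured step isolates this exchange, so the expectation rests on two values alone. Compound 1 also carries a six-membered aromatic ring of carbon only on that carbon and gives 25000 nM in this assay as the sole and weak pointer, which suggests a fall that stops short of that value. The expected step is a 2.6-fold lower number from compound 2 to compound 3 (0.42 log units; beyond the scatter) as a fall in the number, estimated to lie beyond the scatter. Compound 3 is estimated at 70000 nM with an expected range from 20000 nM to 190000 nM for now.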

Compound 3, solubility: 160000 nM
Beside the measured number, compound 3's estimate is 2.3-fold (0.36 log units) below it; low and high end bracket the measured number.
By their numbers in this assay, from the lowest: compound 1; then compounds 3 and 2 (each within the scatter of the next).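

In this assay, for the compounds shown here, this is the first exchange read in one place alone: on an aromatic carbon of the five-membered aromatic ring with 2 nitrogen, 4-aminophenyl in place of pyridin-4-yl gives a 1.2-fold lower number from compound 2 to compound 3 (0.06 log units; within the scatter). In this single pair, then, a six-membered aromatic ring of carbon only carrying a hydrogen-bond donor stands level with a ring holding one hetero atom, so the ring nitrogen of pyridin-4-yl is not required for a number in this range when the 4-bromophenyl group is kept. No measurement on hand offers an explanation for this parity.

Still open, from the compounds shown here alone, is how an unsubstituted phenyl, a 4-hydroxyphenyl or a 4-(dimethylamino)phenyl would read on the same carbon, which would show whether the amine matters to the parity or whether the exchange is tolerated more broadly. Also open, going by these compounds, is how the difference between compound 1 at 25000 nM and compound 2 at 185000 nM divides between the two places where they differ, since compound 1 differs from compound 3 in two places as well.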